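A few compounds are considered here, and "the series" means these few. Any claim that something is new, unique, unknown or untested is made for them only; others in the source may bear on it.

Measured so far:
compound 1 `COc1ccc(-c2nc3sc(-c4ccccc4)cn3n2)cc1`: 42%
compound 2 `C/C(=N/O)c1ccc(NC(=O)Cn2nc(C(F)(F)F)nc2N)cc1`: 5.39%
compound 3 `COc1cc(-c2nc(N)n(CC(=O)Nc3ccc(/C(C)=N\O)cc3)n2)cc(OC)c1OC`: 16.4%

In a functional assay on UACC-62 cells (Homo sapiens) for inhibition, read by sulforhodamine B assay, with a stated time of 48 h, tested at 10 uM (on this read-out lower numbers stand for less inhibition of growth and higher numbers for more inhibition of growth at the one concentration tested), compound 1 gives 42%, the highest of the three numbers. Compound 3 at 16.4% and compound 2 at 5.39% both lie below it, and both gaps are beyond the scatter. Neither compound 2 nor compound 3 shares the core of compound 1, so these values offer no direct guide to a substitution on that core.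

The next compound is compound 4 `COc1ccc(-c2nc3sc(-c4ccc(Cl)cc4)cn3n2)cc1`, which keeps the core of compound 1 and changes one place: phenyl to 4-chlorophenyl. This is chloro in place of hydrogen on an aromatic carbon, para to a large group (chloro in place of hydrogen on an aromatic carbon).

For the measured compounds named here, no measured pair isolates a single change, so the size of this step in this assay cannot be calibrated from the data. The starting point is compound 1 at 42%. A small upward move is expected, most likely not beyond the scatter, and a fall cannot be ruled out. The estimated step is a number 5 percentage points higher from compound 1 to compound 4 (within the scatter). The estimated value for compound 4 is 47%, with an expected range from 29% to 66%.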

Compound 4, percent growth inhibition at one concentration: 31.4%
The estimate for compound 4 lay 15.6 percentage points above the measured number; low and high end bracket the measured number.
By their numbers in this assay, from the lowest: compound 2; then compound 3; then compound 4; then compound 1.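

For the compounds shown here, compound 1 and compound 4 form the only pair that differs in one place, so this position on the shared core now has a first measured step. In this assay, phenyl to 4-chlorophenyl, with chloro in place of hydrogen on an aromatic carbon, para to a large group, gives a number 10.6 percentage points lower from compound 1 to compound 4 (beyond the scatter). The step is modest but shows that growth inhibition at the one concentration tested responds to this single heavy atom, with less inhibition once it is present, and compound 4 still retains 31.4%. No measurement at hand bears on the reason for this fall.

As far as these compounds go, with a single substituent at this position, it remains open whether the fall is particular to chloro or would also appear with another group there, such as a methoxy group, an amine or a carboxylic acid. Also open, from the compounds shown here alone, is whether chloro on another carbon of the same ring, or on the methoxy-bearing ring of the core, would give a step of similar size and direction.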